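Removing the Fluoro from the Aryl Group of Compound 1

The compounds below may be only part of what the source reports. "The series", "measured", "known", "first", "only" and "open" are said of these compounds alone.

The measured compounds:
compound 1, `OC(CCn1nc2c(Br)c(Br)c(Br)c(Br)c2n1)c1ccc(F)cc1`: 46%
compound 2, `OC(CCn1nc2c(Br)c(Br)c(Br)c(Br)c2n1)c1cccc(Cl)c1`: 71%
compound 3, `C[C@@H](O)CCn1nc2c(Br)c(Br)c(Br)c(Br)c2n1`: 69%

In a functional assay on CCRF-CEM cells (Homo sapiens) for antiproliferative activity, read by MTT assay, with a stated time of 24 h, tested at 50 uM (on this read-out higher numbers stand for a weaker effect at the one concentration tested and lower numbers for a stronger effect), compound 1 gives 46%, the lowest of the three numbers and thus the strongest effect among them. Its nearest neighbour is compound 3, which gives 69% in this assay, a gap beyond the scatter; the furthest is compound 2, which gives 71%, also beyond the scatter. Going by the values given here, only one pair of measured compounds differs in a single place, and that step reads a number 25 percentage points higher from compound 1 to compound 2 (beyond the scatter), an exchange of one aryl group for another on the carbon that carries the hydroxyl.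

Compound 4, `OC(CCn1nc2c(Br)c(Br)c(Br)c(Br)c2n1)c1ccccc1`, differs from compound 1 by hydrogen in place of fluoro on an aromatic carbon.

Among the compounds with values here, no measured step removes a halogen from the aryl group while leaving the rest untouched, so the step from compound 1 to compound 4 is not directly anchored. Within the data shown here, the single aryl change on record, from compound 1 to compound 2, moved the number up by a modest margin, and compound 3, with a methyl in place of the whole aryl, likewise sits higher than compound 1. Any departure from the aryl of compound 1 has so far meant a weaker effect, which leads to an expected modest rise, a number 12 percentage points higher from compound 1 to compound 4 (beyond the scatter). Compound 4 is therefore estimated at 58%, with a range from 40% to 78%.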

Compound 4, a percentage reported as activity, at one concentration (the size of the read-out at that concentration, not a potency): 66%
Compound 4: middle estimate off by 8 percentage points, on the low side, within the range that was stated.
By their numbers in this assay, from the lowest: compound 1; then compounds 4, 3 and 2 (each within the scatter of the next).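

The change from 4-fluorophenyl to phenyl reads a number 20 percentage points higher from compound 1 to compound 4 (beyond the scatter) in this assay and gives this position, on an aromatic carbon para to a large group, a measured step of its own: losing the fluoro alone, with nothing else altered, is enough to weaken the effect. The second new step reads a number 5 percentage points lower from compound 2 to compound 4 (within the scatter) and shows that the phenyl of compound 4 and the 3-chlorophenyl of compound 2 cannot be told apart in this assay, so among the three aryl compounds only the 4-fluorophenyl of compound 1 stands apart, and a halogen on the ring is not enough by itself, as compound 2 shows. Nothing in the data shown accounts for this difference.

From the compounds shown here alone, what remains open is whether the step belongs to fluoro in particular or to any group at this place, as a chloro, a methoxy or an amine there would show. Compound 2 cannot settle this, since its 3-chlorophenyl differs from the 4-fluorophenyl of compound 1 in both the halogen and its place on the ring.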